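A few compounds are considered here, and "the series" means these few. Any claim that something is new, unique, unknown or untested is made for them only; others in the source may bear on it.

In a functional assay on MCF7 cells (Homo sapiens) for antiproliferative activity, read by MTT assay, with a stated time of 48 h (a lower number here means a stronger inhibitor, a higher number a weaker inhibitor), compound 1 `CCn1c(C(=O)Nc2ccc(OC(F)(F)F)cc2)ccc1C(CC)(CC)c1ccc(OCCC(O)(CC)CC)c(C)c1` gives > 50000 nM, which is a limit of the assay and not a number. Among the measured compounds shown here, compound 2 `CCOC(=O)C(CC(=O)OC)NC(=O)c1ccc(C(CC)(CC)c2ccc(OCCC(O)(CC)CC)c(C)c2)n1CC` gives 390 nM, the only actual number so far. Between these two lies an at least 120-fold lower number from compound 1 to compound 2 (2.10 log units; beyond the scatter). For the measured compounds named here, that single large step is the only guide, and it involves the same amide-type nitrogen that changes next. Compound 3 `CCC(C)C(NC(=O)c1ccc(C(CC)(CC)c2ccc(OCCC(O)(CC)CC)c(C)c2)n1CC)C(=O)O` differs from compound 2 as follows: a group of 8 heavy atoms (6 carbon, 2 oxygen; no ring) in place of a group of 11 heavy atoms (7 carbon, 4 oxygen; no ring), on an amide-type nitrogen. The new group, 1-carboxy-2-methylbutyl, has not been tested, so a moderate loss is expected, though with much uncertainty. The expected change is a 5.1-fold higher number from compound 2 to compound 3 (0.71 log units; beyond the scatter). The estimate for compound 3 is 2000 nM, with a range from 300 nM to 15000 nM.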

Compound 3, half-maximal inhibitory concentration: 11300 nM
Compound 3: middle estimate off by 5.7-fold (0.75 log units), on the low side, and the stated range covers the measured number.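

In this assay, two groups without a ring on this amide-type nitrogen turn out to be far from equivalent: putting 1-carboxy-2-methylbutyl in place of the group of compound 2 gives a 29-fold higher number from compound 2 to compound 3 (1.46 log units; beyond the scatter). So the absence of a ring is not enough for a low number. Against the 4-(trifluoromethoxy)phenyl group, the same new group gives an at least 4.4-fold lower number from compound 1 to compound 3 (0.64 log units; beyond the scatter), and this step has no fixed size because its starting point is a limit of the assay and not a number: the limit of > 50000 nM in this assay, at which 1 of the 3 values shown sits.

The compounds shown do not separate the effect of the carboxylic acid from that of the branched chain carrying it. From the compounds shown here alone, a methyl ester or an amine on that same chain remains open.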